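Two Diaryl Hydroxyphenyl Analogues and a Third Aryl Swap

The source may hold more compounds than are shown below. What is called first, only, known or untested is meant among the compounds shown, and "the series" means these compounds.

Measured so far:
compound 1 `Oc1cc(C(F)(F)F)ccc1-c1nc(-c2ccccc2O)n(-c2ccc(OC(F)(F)F)cc2)n1`: 84.9%
compound 2 `Oc1cc(C(F)(F)F)ccc1-c1nc(-c2ccccc2O)n(-c2cccc(F)c2)n1`: 87.7%

In a functional assay on PC-12 cells (Rattus norvegicus) for cytotoxicity, read by MTT assay, with stated times of 2 h and 24 h, tested at 5 uM (a lower number here means a weaker effect, a higher number a stronger effect of the compound at the concentration tested), compound 2 gives 87.7% and compound 1 gives 84.9%; the two numbers lie within the scatter of each other, as the step of a number 2.8 percentage points higher from compound 1 to compound 2 (within the scatter) shows. Compound 3 `Cc1ccc(-n2nc(-c3ccc(C(F)(F)F)cc3O)nc2-c2ccccc2O)c(C)c1` differs from compound 2 in one place: 2,4-dimethylphenyl in place of 3-fluorophenyl on an aromatic nitrogen. Among the compounds with values here, the only measured step that bears on this change is a number 2.8 percentage points higher from compound 1 to compound 2 (within the scatter), which also exchanged the group on the aromatic nitrogen and stayed within the scatter. Compound 3 is therefore expected to give 85% in this assay, with a range from 74% to 94%. The expected step is a number 2.7 percentage points lower from compound 2 to compound 3 (within the scatter), nothing beyond the scatter.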

Compound 3, a percentage reported as activity, at one concentration (the size of the read-out at that concentration, not a potency): 93.3%
Compound 3: the middle estimate sits 8.3 percentage points below what was measured, and the stated range covers the measured number.
By their numbers in this assay, from the lowest: compounds 1, 2 and 3 (each within the scatter of the next).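

On the aromatic nitrogen, 2,4-dimethylphenyl, an aryl group of carbon only, now stands alongside the two fluorine-bearing aryl groups, and this assay gives a number 5.6 percentage points higher from compound 2 to compound 3 (within the scatter) and a number 8.4 percentage points higher from compound 1 to compound 3 (within the scatter). Even with both fluorine-bearing groups gone, this position has therefore not separated any of the three aryl groups beyond the scatter. Nothing available here accounts for these numbers. From the compounds shown here alone, it remains open whether a phenyl ring carrying a carboxylic acid or an amine on this nitrogen would move the number beyond the scatter.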